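The source may hold more compounds than are shown below. What is called first, only, known or untested is meant among the compounds shown, and "the series" means these compounds.

Among the compounds with values here, compound 1, `CCCCNc1nc(N)c2nc(O)n(Cc3ccccc3)c2n1`, is the one compound here that comes with a full number. In a functional assay (spleen, spleen) for activation, with Mus musculus as the target (a lower number here means that less compound is needed, a higher number that more compound is needed for the effect), compound 1 gives 1 uM. Compound 2, `Nc1ncnc2c1nc(I)n2Cc1ccccc1`, sits at a limit of the assay and not at a number, for in this assay compound 2 gives > 10 uM. Of the two values shown, that is where (the limit of > 10 uM in this assay, at which 1 of the 2 values shown sits).

Compound 3, `Nc1nc(S)nc2c1nc(O)n2Cc1ccccc1`, has not yet been measured. It differs from compound 1 in one place: sulfanyl in place of butylamino on an aromatic carbon. Within the data shown here, no two measured compounds that differ in only one place are available, so no measured step shows what this kind of change does. The expectation is that losing the butylamino chain will cost activity, so that from compound 1 to compound 3 a step of a 5.0-fold higher number from compound 1 to compound 3 (0.70 log units; beyond the scatter) toward more compound is expected, beyond the usual scatter. Compound 3 is estimated to give 5 uM, with a range from 1 uM to 20 uM.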

Compound 3, minimum effective concentration: 10 uM
Beside the measured number, compound 3's estimate is 2.0-fold (0.30 log units) below it; the measured number falls inside the stated range.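

In this assay, replacing butylamino with sulfanyl on this aromatic carbon, between two ring nitrogen atoms, gives a 10-fold higher number from compound 1 to compound 3 (1.00 log units; beyond the scatter) and so provides the first measured sign that the group at this position matters. The effect does not vanish with the butylamino group: compound 3 still gives 10 uM, so more compound is needed but a full number remains. The two groups match in their counts of hydrogen-bond donors and acceptors and in net charge, yet they differ in heavy atoms and element, and nothing shown explains the size of this step.

This single change cannot separate the loss of the four-carbon chain from the arrival of sulfur. Ethylamino, hexylamino, butoxy or a plain amine at this carbon would be needed to tell those two apart.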